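Working notes on a halogenated benzyl series

The compounds below may be only part of what the source reports. "The series", "measured", "known", "first", "only" and "open" are said of these compounds alone.

Measured so far:
compound 1 `OC[C@H]1O[C@@H](n2cnc3c(NCc4cccc(F)c4)ncnc32)[C@H](O)[C@@H]1O`: > 166000 nM
compound 2 `OC[C@H]1O[C@@H](n2cnc3c(NCc4ccccc4Br)ncnc32)[C@H](O)[C@@H]1O`: > 166000 nM
compound 3 `OC[C@H]1O[C@@H](n2cnc3c(NCc4cccc(Br)c4)ncnc32)[C@H](O)[C@@H]1O`: > 166000 nM

In a functional assay on HOS cells (Homo sapiens) for antiproliferative activity, with a stated time of 72 h (on this read-out lower numbers stand for stronger inhibition and higher numbers for weaker inhibition), the value of compound 1 is a limit of the assay, not a number. The value of compound 2 in this assay is likewise a limit. Compound 3 in this assay also reaches only a limit, so compound 3 stands at the ceiling of what this read-out could resolve, in the same place as the two other entries (the limit of > 166000 nM in this assay, at which 3 of the 3 values shown sit). With every value a limit, the three steps among the measured compounds cannot be sized: a step that the two limits leave unreadable from compound 1 to compound 2, a step that the two limits leave unreadable from compound 1 to compound 3 and a step that the two limits leave unreadable from compound 2 to compound 3 are all unreadable in this assay.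

Compound 4 `OC[C@H]1O[C@@H](n2cnc3c(NCc4ccc(F)c(F)c4F)ncnc32)[C@H](O)[C@@H]1O` differs from compound 3 in one place: 2,3,4-trifluorophenyl in place of 3-bromophenyl on a saturated chain carbon bound to a nitrogen on an aromatic ring. Each of the three steps among compound 1, compound 2 and compound 3 also exchanges one halogenated phenyl for another on the same saturated chain carbon, but none of them gives a readable size, so none of them bears on the expected direction or size of a step that the limit leaves unreadable from compound 3 to compound 4, which is expected to lie within the scatter. Since compound 1, compound 2 and compound 3 all sit at the limit, compound 4 is expected to give 200000 nM in this assay, within 50000 nM to 600000 nM, most probably again as a limit only.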

Compound 4, half-maximal inhibitory concentration: > 166000 nM
Compound 4 gave a limit, no number; the forecaster's own chance of this, stated with the estimate: 85%; the middle value does not contradict the limit.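

In this assay compound 4 gives > 166000 nM, a limit and not a number. Within the data shown here, no step among compound 1, compound 2, compound 3 and compound 4 can be read, with all of them at the same limit: the limit of > 166000 nM in this assay, at which 4 of the 4 values shown sit. The compounds shown leave open whether any halogenated phenyl group on the shared core gives a readable value in this assay, and how these groups would rank.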